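Capping the hydroxy group: from compound 1 to compound 3

The source may hold more compounds than are shown below. What is called first, only, known or untested is meant among the compounds shown, and "the series" means these compounds.

Measured so far:
compound 1 `Cn1c(Cc2nn(C)c(=O)c3ccccc23)nnc1SCCCCCCCC(=O)Nc1ccc(O)cc1`: > 30000 nM
compound 2 `COc1ccc(NC(=O)CSc2nnc(Cc3nn(C)c(=O)c4ccccc34)n2C)cc1`: "not active" (no number reported)

In an assay on isolated protein (Mus musculus) for inhibition of IL15-IL15 receptor (Homo sapiens), read by resazurin assay, with stated times of 30 min and 2.5 days (a lower number here means a stronger inhibitor, a higher number a weaker inhibitor), compound 1 gives > 30000 nM, which is a limit of the assay rather than a number. Compound 2 is reported in this assay as "not active" (no number reported). Among the compounds with values here, compound 1 thus stands at the limit of > 30000 nM in this assay, at which 1 of the 2 values shown sits, and there is no measured step between two compounds to show how any single change shifts the read-out.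

Compound 3 `COc1ccc(NC(=O)CCCCCCCSc2nnc(Cc3nn(C)c(=O)c4ccccc34)n2C)cc1` is compound 1 with one small change: methyl in place of hydrogen on an oxygen on an aromatic ring. Both measured compounds show no inhibition, so there is nothing to suggest that this change would bring activity. The expected step is a step that the limit leaves unreadable from compound 1 to compound 3, no more than the scatter. Compound 3 is estimated at 50000 nM, between 20000 nM and 150000 nM, and is most likely to be reported only as a limit again.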

Compound 3, half-maximal inhibitory concentration: 3900 nM
Compound 3: middle estimate off by 13-fold (1.11 log units), on the high side, outside the stated range (below it).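

The capped oxygen matters: in this assay, methyl in place of hydrogen on the oxygen gives an at least 7.6-fold lower number from compound 1 to compound 3 (0.88 log units; beyond the scatter), and this yields the first measurable inhibition among the compounds shown. A free hydroxy group is therefore not required for inhibition in this series. From the compounds shown here alone, the true size of the step stays unknown because compound 1 gives only a limit of the assay, not a number: the limit of > 30000 nM in this assay, at which 1 of the 3 values shown sits.

Methoxy alone is not enough, since compound 2 carries the same 4-methoxyphenyl group on a shorter chain and is reported as not active. Still open, going by these compounds, is whether an ethoxy group or an amine at this place would keep the inhibition, and how a chain of intermediate length would read.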